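The compounds below may be only part of what the source reports. "The series", "measured", "known", "first", "only" and "open" are said of these compounds alone.

Compound 1 `COc1ccc(N2C(=O)NC3(CSC4=C3C(=O)c3ncccc3C4=O)C2=O)cc1` gives the lowest number of the three compounds measured in a functional assay on HeLa cells (Homo sapiens) for antiproliferative activity, read by MTT assay, with a stated time of 96 h (a lower number here means a stronger inhibitor, a higher number a weaker inhibitor), at 1 nM. Compound 2 `O=C1NNC(=O)C2(CSC3=C2C(=O)c2ncccc2C3=O)N1` gives 980 nM in this assay, and compound 3 `O=C1NN(c2ccc([N+](=O)[O-])cc2)C(=O)C2(CSC3=C2C(=O)c2ncccc2C3=O)N1` gives 610 nM. For the measured compounds named here, the step of a 1.6-fold lower number from compound 2 to compound 3 (0.21 log units; within the scatter) is the only single change measured; it exchanges a substituent on an amide-type nitrogen in a ring, but on a different core and from hydrogen rather than from an aryl group. Compound 4 `O=C1C2=C(C(=O)c3ncccc31)C1(CS2)NC(=O)N(c2ccncc2)C1=O` differs from compound 1 by pyridin-4-yl in place of 4-methoxyphenyl on an amide-type nitrogen in a ring. Going by the values given here, no measured step sets one six-membered aromatic ring against another on that nitrogen, so compound 1 is the only anchor. Because compound 1 gives 1 nM and one six-membered aromatic ring is kept on that nitrogen, compound 4 is expected at 5 nM, from 1 nM to 40 nM, a step of a 5.0-fold higher number from compound 1 to compound 4 (0.70 log units; beyond the scatter).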

Compound 4, half-maximal inhibitory concentration: 10 nM
For compound 4 the middle estimate is 2.0-fold (0.30 log units) below the measured one, within the range that was stated.
By their numbers in this assay, from the lowest: compound 1; then compound 4; then compounds 3 and 2 (each within the scatter of the next).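

In this assay, for the compounds shown here, the exchange on the amide-type nitrogen gives a 10-fold higher number from compound 1 to compound 4 (1.00 log units; beyond the scatter), so this position responds to swapping one six-membered aromatic ring for another, which the earlier compounds could not show. The change replaces a carbon-only ring with one holding a hetero atom and also removes the methoxy group, and the step cannot separate these two differences. Nothing available bears on the reason for this step. On these data alone, it remains open whether a plain phenyl group, with neither the methoxy group nor the ring nitrogen, would stand nearer compound 1 or compound 4.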